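The compounds below may be only part of what the source reports. "The series", "measured", "known", "first", "only" and "open" are said of these compounds alone.

Of the compounds shown here, three share one core and have been tested in a functional assay on the whole organism for inhibition, with Mus musculus as the target, at a dose of 1 mg/kg by the oral route; on this read-out lower numbers stand for less inhibition and higher numbers for more inhibition at the one dose given (going by the name of the read-out). Compound 1, `CN(C(=O)c1c(O)c2c(C(F)(F)F)cccc2n(C)c1=O)c1ccccc1`, gives 99% in this assay. Compound 2, `CCN(C(=O)c1c(O)c2c(C(F)(F)F)cccc2n(C)c1=O)c1ccccc1`, gives 80%, and compound 3, `COc1cccc2c1c(O)c(C(=O)N(C)c1ccc(F)cc1F)c(=O)n2C`, gives 88%. Compound 1 therefore stands highest of the three numbers in this assay: compound 3 comes nearest to it and compound 2 lies furthest away, both beyond the scatter.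

Going by the values given here, the only single-site step among the measured compounds runs from compound 1 to compound 2 and brings a number 19 percentage points lower from compound 1 to compound 2 (beyond the scatter), a change of methyl in place of hydrogen on a saturated chain carbon bound to an amide-type nitrogen. Compound 3 differs from compound 1 in more than one place, so its value can only be set beside that of compound 1 without a step being drawn.

Compound 4, `CN(C(=O)c1c(O)c2c([N+](=O)[O-])cccc2n(C)c1=O)c1ccccc1`, has not yet been measured in this assay. It differs from compound 1 by nitro in place of trifluoromethyl on an aromatic carbon. Among the compounds with values here, the one measured step concerns a different part of the molecule and does not bear directly on this exchange, so the expectation rests on the high value of compound 1 alone. Compound 4 is estimated to give 85% in this assay, within 55% to 99%, which means an expected step of a number 14 percentage points lower from compound 1 to compound 4 (beyond the scatter).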

Compound 4, a percentage reported as inhibition, in the whole organism at one dose (the size of the read-out at that dose, not a potency): 96%
Compound 4: middle estimate off by 11 percentage points, on the low side; the measured number falls inside the stated range.
By their numbers in this assay, from the lowest: compounds 2, 3, 4 and 1 (each within the scatter of the next, the first and the last beyond it).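

Exchanging trifluoromethyl for nitro on this aromatic carbon brings a number 3 percentage points lower from compound 1 to compound 4 (within the scatter) in this assay, so at the one dose given, this read-out does not separate the two groups in this pair. Going by these compounds alone, the only earlier step, a number 19 percentage points lower from compound 1 to compound 2 (beyond the scatter), lay in the chain on the amide nitrogen and said nothing about the aromatic ring; this pair now shows that, with the rest of compound 1 unchanged, trifluoromethyl is not required at this position for a high number. No measurement shown gives a reason why the two groups read so much alike.

The compounds shown leave open whether the high number survives with an amine, a carboxylic acid or a plain hydrogen on this aromatic carbon, and whether nitro would give the same result alongside the longer chain on the amide nitrogen of compound 2. Since the read-out comes from a single dose, it also leaves open whether compound 1 and compound 4 would still read alike at lower doses.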